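From Methyl to Benzyl: What Dose to Expect?

The source may report more compounds than this note shows. Statements on the series, on what has been measured and on what is new or still open speak of the compounds shown alone.

In a functional assay on the whole organism for inhibition, with Cavia porcellus as the target (a lower number here means that less compound is needed, a higher number that more compound is needed for the effect), compound 1 `CCCC(=O)CC(=O)N1CCSC1COc1ccccc1OC` gives 42 mg/kg and compound 2 `COc1ccccc1OCC1SCCN1C(=O)CC(=O)N1CCN(C)CC1` gives 27 mg/kg. These two numbers lie within the scatter of each other, so compound 2 cannot be told apart from compound 1 on this measure.

Compound 3 `COc1ccccc1OCC1SCCN1C(=O)CC(=O)N1CCN(Cc2ccccc2)CC1` is compound 2 with one change: phenyl in place of hydrogen on a saturated chain carbon bound to an amine nitrogen in a ring. Put briefly, the methyl of compound 2 becomes a benzyl in compound 3.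

Among the compounds with values here, only one measured step bears on this change: a 1.6-fold lower number from compound 1 to compound 2 (0.19 log units; within the scatter). In that step, 4-methylpiperazin-1-yl stands in place of propyl on a carbonyl carbon, and the numbers stay within the scatter. Within the data shown here, it is a single step at a different place, and no measured compound carries a benzyl group, so the data point in no direction. No shift beyond the scatter is therefore expected in this assay.

The expected size of the change is no change at the digits printed from compound 2 to compound 3 (within the scatter). For compound 3 the estimated dose is 27 mg/kg, with an expected range from 11 mg/kg to 65 mg/kg.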

Compound 3, dose for half-maximal effect: 41 mg/kg
Compound 3: middle estimate off by 1.5-fold (0.18 log units), on the low side; measured number inside the range.
By their numbers in this assay, from the lowest: compounds 2, 3 and 1 (each within the scatter of the next).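

Within the data shown here, the step from methyl to benzyl gives a 1.5-fold higher number from compound 2 to compound 3 (0.18 log units; within the scatter) in this assay, so the first look at this position shows that it can take a phenyl, with its 6 heavy atoms and aromatic ring, and the dose cannot be told apart from that of compound 2. The earlier step changed a different place and could say nothing about this one, whereas this pair isolates the saturated chain carbon bound to an amine nitrogen in a ring, with the rest of the structure held the same. Nothing available explains why the dose stays within the scatter after so large an addition to the structure.

Still open, on these data alone, is whether any group at this place can move the dose beyond the scatter, for example a longer chain such as butyl, a carboxylic acid on the chain, or a phenyl ring carrying a chlorine atom. With a single pair at this position, the result also cannot show whether the same swap would behave alike on a different core, such as one with another group in place of the methoxy.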